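This account rests on a few compounds, and the source may have more. Where it says the series, first, only, none or still open, it means among the compounds named here.

In a functional assay on HCT-116 cells (Homo sapiens) for antiproliferative activity, read by MTT assay, with a stated time of 48 h (on this read-out lower numbers stand for stronger inhibition and higher numbers for weaker inhibition), compound 1 `COc1ncc(-c2ccc3nc(NC(=O)C4CC4)nn3c2)cc1NS(=O)(=O)c1ccc(F)cc1` gives 1740 nM, the lower of the two measured numbers, while compound 2 `O=C(Nc1nc2ccc(-c3cnc(Cl)c(NS(=O)(=O)c4ccc(F)cc4)c3)cn2n1)C1CC1` gives 9980 nM. Compound 3 `CCOC(=O)CNc1nc2ccc(-c3cnc(OC)c(NS(=O)(=O)c4ccc(F)cc4)c3)cn2n1` has (ethoxycarbonyl)methyl in place of cyclopropylcarbonyl on a nitrogen on an aromatic ring. Among the compounds with values here, the only measured step, a 5.7-fold higher number from compound 1 to compound 2 (0.76 log units; beyond the scatter), is a different change, chloro in place of methoxy, so it offers only a rough scale. Within the data shown here, no measured compound tests the new change, but a modest rise in this assay is expected. The expected change is a 3.4-fold higher number from compound 1 to compound 3 (0.54 log units; beyond the scatter). For compound 3, the estimated value is 6000 nM, with an expected range of 1800 nM to 20000 nM.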

Compound 3, half-maximal inhibitory concentration: 4370 nM
The estimate for compound 3 lay 1.4-fold (0.14 log units) above the measured number; the range from low to high includes it.
By their numbers in this assay, from the lowest: compound 1; then compound 3; then compound 2.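

In this assay, within the data shown here, the step at this nitrogen on an aromatic ring gives a 2.5-fold higher number from compound 1 to compound 3 (0.40 log units; beyond the scatter), the first measure of change at this place rather than at the methoxy carbon. Replacing cyclopropylcarbonyl with (ethoxycarbonyl)methyl removes the three-membered ring and costs only a modest step in this read-out. Nothing measured here explains that step. The compounds shown leave open whether the step follows the lost ring or the ester. A carboxylic acid in place of the ethyl ester, or an acetyl group on that nitrogen, would test those two parts separately.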